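The compounds below may be only part of what the source reports. "The series", "measured", "known", "first", "only" and "open" are said of these compounds alone.

Compound 1 `O=C1CCC[C@H]([C@@H]2C[C@H]2c2ccccc2)O1` is the starting point of this step. In a functional assay on A549 cells (Homo sapiens) for antiproliferative activity, read by luminescence and CellTiter-Glo, with a stated time of 48 h (on this read-out higher numbers stand for weaker inhibition and lower numbers for stronger inhibition), compound 1 gives only a limit, > 100000 nM, so no number was reached within the measured range. That limit is the one described by the limit of > 100000 nM in this assay, at which 1 of the 3 values shown sits. Two further compounds share much of the same skeleton but carry an unsaturated lactone: compound 2 `O=C1C=CC[C@H](/C=C/c2ccc([N+](=O)[O-])cc2)O1` gives 15400 nM in this assay, and compound 3 `O=C1C=CC[C@@H]([C@H]2C[C@@H]2c2ccccc2)O1` gives 15200 nM in this assay; these two values lie within the scatter of each other. Compound 4 `O=C1CCC[C@H]([C@H]2C[C@@H]2c2ccccc2)O1` has not yet been measured. It differs from compound 1 only in configuration: the two compounds have the same atoms and bonds and differ only in configuration as drawn: 2 of 3 stereo elements differ; a stereocentre at a saturated ring carbon is drawn R in compound 1 and S in compound 4; a stereocentre at a saturated ring carbon is drawn R in compound 1 and S in compound 4. For the measured compounds named here, no measured pair here isolates such a change of configuration alone, so the size of the step in this assay cannot be read from the numbers, and with compound 1 sitting at a limit no direction can be inferred either. Compound 4 is expected to land near 100000 nM, between 30000 nM and 300000 nM, and the expected step of a number no higher from compound 1 to compound 4 (the limit leaves the size open) is therefore small, with a real chance that only a limit is reported again.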

Compound 4, half-maximal inhibitory concentration: > 100000 nM
Compound 4: only a limit was reported; the forecaster's own chance of this, stated with the estimate: 60%; the middle value sits exactly at the limit.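

Compound 1 and compound 4 each give only a limit in this assay, so no step between them can be read: the limit of > 100000 nM in this assay, at which 2 of the 4 values shown sit.

The compounds shown leave open whether the change of configuration alone alters antiproliferative activity, and what the true values of compound 1 and compound 4 are.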